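A few compounds are considered here, and "the series" means these few. Any claim that something is new, unique, unknown or untested is made for them only; others in the source may bear on it.

Compound 1 `Nc1ccc(S(=O)(=O)N2CCN(c3ncc(C(O)(C(F)(F)F)C(F)(F)F)cc3C3CC3)CC2)cn1`: 38 mL.min-1.g-1
Compound 2 `Nc1ccc(S(=O)(=O)N2CCN(c3ncc(C(O)(C(F)(F)F)C(F)(F)F)cc3-c3cncc(F)c3)CC2)cn1`: 24 mL.min-1.g-1
Compound 3 `Nc1ccc(S(=O)(=O)N2CCN(c3ncc(C(O)(C(F)(F)F)C(F)(F)F)cc3-c3ccc4[nH]ncc4c3)CC2)cn1`: 27 mL.min-1.g-1

These three compounds share one core and differ only in a single group, and all were tested in an ADME assay (liver) for metabolic stability, with Liver microsome (Homo sapiens) as the target, using microsomes and NADPH, with a stated time of 30 min, tested at 1 uM; a higher number here means faster removal of the compound, a lower number slower removal. On these numbers, compound 3 at 27 mL.min-1.g-1 cannot be told apart from the other two: the data show a 1.4-fold lower number from compound 1 to compound 3 (0.15 log units; within the scatter) and a 1.1-fold higher number from compound 2 to compound 3 (0.05 log units; within the scatter).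

Compound 4 `Nc1ccc(S(=O)(=O)N2CCN(c3ncc(C(O)(C(F)(F)F)C(F)(F)F)cc3-c3cccc4[nH]ncc34)CC2)cn1` has the same atoms as compound 3, joined differently: 1H-indazol-4-yl in place of 1H-indazol-5-yl on an aromatic carbon. In short, 1H-indazol-4-yl takes the place of 1H-indazol-5-yl, with the attachment point on the indazole moved while the rest stays the same.

The closest evidence comes from the other changes at this same place, which include a 1.6-fold lower number from compound 1 to compound 2 (0.20 log units; within the scatter) as well. Even replacing cyclopropyl with an indazole gave only a 1.4-fold lower number from compound 1 to compound 3 (0.15 log units; within the scatter). Going by the values given here, no measured pair compares two attachment points of an indazole, so this evidence is indirect.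

The expected result is no change at the digits printed from compound 3 to compound 4 (within the scatter), with no step beyond the scatter. For compound 4 the estimated value is 27 mL.min-1.g-1, with an expected range from 15 mL.min-1.g-1 to 46 mL.min-1.g-1.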

Compound 4, intrinsic clearance in microsomes: 42 mL.min-1.g-1
Estimate against measurement, compound 4: 1.6-fold (0.19 log units) below, and the stated range covers the measured number.
By their numbers in this assay, from the lowest: compounds 2, 3, 1 and 4 (each within the scatter of the next).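

Moving the attachment point on the indazole keeps the same atoms, and in this assay it gives a 1.6-fold higher number from compound 3 to compound 4 (0.19 log units; within the scatter) for 1H-indazol-4-yl in place of 1H-indazol-5-yl, so even this change stays within the scatter. The comparisons with the other groups read the same way, with a 1.8-fold higher number from compound 2 to compound 4 (0.24 log units; within the scatter) and a 1.1-fold higher number from compound 1 to compound 4 (0.04 log units; within the scatter) as well, which leaves cyclopropyl, 5-fluoropyridin-3-yl and both indazoles all within the scatter of one another at this place. No measurement shown here accounts for the size of these steps.

Still open, as far as these compounds go, is whether a different kind of group at this position, such as an amine or a carboxylic acid, would give a step beyond the scatter. The compounds shown also leave open whether any change elsewhere on the shared core would do so.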